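The source may report more compounds than this note shows. Statements on the series, on what has been measured and on what is new or still open speak of the compounds shown alone.

Compound 2, whose structure is `CC1(C)Oc2ccc(Cc3ccccc3)cc2[C@@H](/N=C(\NC#N)Nc2ccc(Cl)cc2)[C@@H]1O`, gives 10000 nM in a functional assay (aorta) with Rattus norvegicus as the target; on this read-out higher numbers stand for weaker inhibition and lower numbers for stronger inhibition. Among the three compounds measured so far it holds the second highest number. Its closest neighbour is compound 3, `C=C(c1ccccc1)c1ccc2c(c1)[C@@H](/N=C(\NC#N)Nc1ccc(Cl)cc1)[C@H](O)C(C)(C)O2`, which gives 10700 nM; the change amounts to a 1.1-fold higher number from compound 2 to compound 3 (0.03 log units; within the scatter). The compound furthest from it is compound 1, `CC1(C)Oc2ccc(C#N)cc2[C@@H](/N=C(\NC#N)Nc2ccc(Cl)cc2)[C@@H]1O`, which gives 1800 nM; here the change is a 5.6-fold higher number from compound 1 to compound 2 (0.74 log units; beyond the scatter). Compound 1 and compound 3 are separated by a 5.9-fold higher number from compound 1 to compound 3 (0.77 log units; beyond the scatter).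

Compound 4, `CC1(C)Oc2ccc(S(=O)(=O)c3ccccc3)cc2[C@@H](/N=C(\NC#N)Nc2ccc(Cl)cc2)[C@@H]1O`, has not been measured. It differs from compound 2 in one place: phenylsulfonyl in place of benzyl on an aromatic carbon. Two of the measured steps bear on this. Going from compound 1 to either of the other two, a small cyano group was exchanged for a larger group carrying a phenyl ring, and both steps raised the number by a modest, clearly visible amount. Exchanging one phenyl-bearing group for another, as in the step from compound 2 to compound 3, left the number essentially unchanged. The change to compound 4 is again an exchange of one phenyl-bearing group for another, so the expected step is no change at the digits printed from compound 2 to compound 4 (within the scatter), a step not clearly beyond the scatter. The expected value for compound 4 in this assay is therefore 10000 nM, with a likely range from 4000 nM to 25000 nM.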

Compound 4, half-maximal inhibitory concentration: 500 nM
Compound 4: middle estimate off by 20-fold (1.30 log units), on the high side; the whole stated range lies above it.
By their numbers in this assay, from the lowest: compound 4; then compound 1; then compounds 2 and 3 (each within the scatter of the next).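

In this assay, among these compounds, the earlier compounds suggested that groups carrying a phenyl ring at this aromatic carbon all give much the same number, but phenylsulfonyl breaks that picture with a 20-fold lower number from compound 2 to compound 4 (1.30 log units; beyond the scatter) and with a 21-fold lower number from compound 3 to compound 4 (1.33 log units; beyond the scatter) as well, so the presence of a phenyl ring does not alone set the number here. The result also overturns the earlier impression that replacing the small cyano group with something larger raises the number, since phenylsulfonyl brings a 3.6-fold lower number from compound 1 to compound 4 (0.56 log units; beyond the scatter) and thus goes against the trend set by compound 2 and compound 3. What separates phenylsulfonyl from benzyl is the link to the ring, a sulfur bearing two oxygens in place of a single carbon, yet no data here explain why this link matters so much and the question stays unanswered.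

The compounds shown leave open whether a carbonyl link, as in a benzoyl group, or a plain ether oxygen, as in a phenoxy group, would match the sulfonyl link. They also leave open whether the phenyl ring is needed at all, which a methylsulfonyl group would address.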